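Chain extension between aromatic oxygen and amine

The compounds below may be only part of what the source reports. "The series", "measured", "known", "first", "only" and "open" are said of these compounds alone.

Measured compounds:
compound 1, `COc1c(OCCCCN2CCN(C)CC2)cc(O)c2c(=O)cc(-c3ccc([N+](=O)[O-])cc3)oc12`, 2890 nM
compound 2, `COc1c(OCCCCN2CCN(C)CC2)cc(O)c2c(=O)cc(-c3ccc(F)cc3Br)oc12`, 3440 nM
compound 3, `CCN(CC)CCCOc1c(OCc2ccccc2)cc(O)c2c(=O)cc(-c3ccccc3)oc12`, 4900 nM

For the measured compounds named here, in a functional assay on B16 cells (Mus musculus) for cytotoxicity, read by MTT assay, with a stated time of 72 h (a higher number here means a weaker inhibitor, a lower number a stronger inhibitor), compound 1 gives 2890 nM and compound 2 gives 3440 nM; the one step between them, a 1.2-fold higher number from compound 1 to compound 2 (0.08 log units; within the scatter), concerns the aryl group on the shared core and not the amine-bearing chain. Compound 3 gives 4900 nM; its number sits nearest to that of compound 2 and furthest from that of compound 1, and both gaps lie within the scatter, so the three numbers are not separated from one another.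

Compound 4, `CCN(CC)CCCCOc1c(OCc2ccccc2)cc(O)c2c(=O)cc(-c3ccccc3)oc12`, differs from compound 3 by (diethylamino)methyl in place of diethylamino on a saturated chain carbon, three bonds along the chain from an oxygen on an aromatic ring. Going by the values given here, no measured pair in the set changes the length of this chain, and the only step on record concerns another position and is itself within the scatter. Nothing here therefore points to a shift in either direction, and the step of no change at the digits printed from compound 3 to compound 4 (within the scatter) is expected to stay within the scatter. For compound 4 the estimate in this assay is 4900 nM, with a range from 2000 nM to 12000 nM.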

Compound 4, half-maximal inhibitory concentration: 4880 nM
Compound 4: the middle estimate sits 1.0-fold (0.00 log units) above what was measured; the measured number falls inside the stated range.
By their numbers in this assay, from the lowest: compounds 1, 2, 4 and 3 (each within the scatter of the next).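

In this assay, for the compounds shown here, the step of a 1.0-fold lower number from compound 3 to compound 4 (0.00 log units; within the scatter) is the only reading on the length of the chain that carries the amine, and it lies within the scatter. At this position, the numbers for the 3-(diethylamino)propyl and 4-(diethylamino)butyl chains are therefore not separated, which the earlier step could not show because it concerned the aryl group and left the chain untouched. This holds for this one pair, with its diethylamino end and the rest of the structure kept constant, and no supporting measurement is available to explain the result.

On these data alone, it remains open whether a shorter 2-(diethylamino)ethyl chain or a longer 5-(diethylamino)pentyl chain would also stay within the scatter of these two compounds, since a single step cannot define a trend across chain lengths. As far as these compounds go, it is also open whether the same change would read alike with a pyrrolidine or morpholine in place of diethylamino, or on the background of compound 1, where the chain ends in a different amine and the aryl group carries a nitro substituent.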